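The source may report more compounds than this note shows. Statements on the series, on what has been measured and on what is new or still open speak of the compounds shown alone.

For the measured compounds named here, compound 3, with the structure `CN1CCCN(CCn2ccc3ccc(OCc4ccccc4)cc32)CC1`, is one of three compounds measured in an assay on HEK293 cells for binding affinity to 5-hydroxytryptamine receptor 7 (Homo sapiens), read by radioligand binding, tested at 1 uM (on this read-out lower numbers stand for less inhibition and higher numbers for more inhibition at the one concentration tested (going by the name of the read-out)), where compound 3 gives 28%. Compound 2, `CN1CCCN(CCn2ccc3ccc(O)cc32)CC1`, gives 28% in this assay, and no change at the digits printed from compound 2 to compound 3 (within the scatter). Compound 1, `CN1CCCN(CCn2ccc3ccc(F)cc32)CC1`, gives 60%, so compound 3 stands level with compound 2 at the digits shown, the two together the lowest of the three numbers, with compound 1 the furthest away.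

Compound 4 has the structure `CC(C)c1ccc2ccn(CCN3CCCN(C)CC3)c2c1`. Its difference from compound 3 is isopropyl in place of benzyloxy on an aromatic carbon.

Going by the values given here, two measured steps bear on this change. Both replace the fluoro of compound 1 with an oxygen-bearing group: a number 32 percentage points lower from compound 1 to compound 2 (beyond the scatter) and a number 32 percentage points lower from compound 1 to compound 3 (beyond the scatter). Read in the other direction, removing the benzyloxy or hydroxy in favour of fluoro goes with a large rise, whereas no change at the digits printed from compound 2 to compound 3 (within the scatter) shows that swapping hydrogen for benzyl on the oxygen does nothing beyond the scatter. Among the compounds with values here, no measured step introduces isopropyl, so the size of the step is uncertain, but the loss of the benzyloxy is what the data speak to.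

Compound 4 is therefore expected to move upward from compound 3 by a number 17 percentage points higher from compound 3 to compound 4 (beyond the scatter). The estimate for compound 4 in this assay is 45%, within a range from 20% to 70%.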

Compound 4, a percentage reported as inhibition, at one concentration (the size of the read-out at that concentration, not a potency): 72%
Compound 4: the middle estimate sits 27 percentage points below what was measured; measured number outside the range, above it.
By their numbers in this assay, from the lowest: compounds 2 and 3 (each within the scatter of the next); then compound 1; then compound 4.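

At this position on the aromatic carbon, in this assay, isopropyl in place of benzyloxy goes with a number 44 percentage points higher from compound 3 to compound 4 (beyond the scatter) and isopropyl in place of hydroxy with a number 44 percentage points higher from compound 2 to compound 4 (beyond the scatter), so the earlier fall on leaving fluoro now has a counterpart in a large rise on leaving either oxygen-bearing group. The change is more than a return to the level of the fluoro compound, since isopropyl in place of fluoro goes with a number 12 percentage points higher from compound 1 to compound 4 (beyond the scatter), which places a group that carries no oxygen at the top of the four numbers. Among these four compounds, the two with oxygen attached at this position sit level at the bottom and the two without it sit higher, with none going against that division, but nothing given here accounts for it.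

The compounds shown leave open whether a methoxy group would stay with the oxygen-bearing pair, and whether a tert-butyl or cyclopropyl group would keep the number as high as isopropyl does. They also leave open where an amine such as dimethylamino would fall, and whether the order would hold for potency rather than for inhibition at one concentration.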